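Swapping the Butyl Chain for a Fluorophenyl Ring

This account rests on a few compounds, and the source may have more. Where it says the series, first, only, none or still open, it means among the compounds named here.

Measured compounds:
- compound 1, `CCCCc1cn(C(c2ccccc2)c2cc3cc(Br)ccc3nc2OC)nn1`: -3.47%
- compound 2, `CCCCCc1cn(C(c2ccccc2)c2cc3cc(Br)ccc3nc2OC)nn1`: -2%
- compound 3, `COc1nc2ccc(Br)cc2cc1C(c1ccccc1)n1cc(CCCO)nn1`: 27.4%

In an ADME assay on HEK293 cells (Homo sapiens) for cytotoxicity, read by sulforhodamine B assay, with a stated time of 48 h, tested at 10 uM (on this read-out lower numbers stand for less inhibition and higher numbers for more inhibition at the one concentration tested (going by the name of the read-out)), compound 1 gives the lowest of the three numbers. Compound 2 sits closest, with a number 1.5 percentage points higher from compound 1 to compound 2 (within the scatter), so these two cannot be told apart. Compound 3 lies far off, with a number 30.9 percentage points higher from compound 1 to compound 3 (beyond the scatter), and the step of a number 29.4 percentage points higher from compound 2 to compound 3 (beyond the scatter) points the same way.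

Compound 4, `COc1nc2ccc(Br)cc2cc1C(c1ccccc1)n1cc(-c2cccc(F)c2)nn1`, differs from compound 1 by 3-fluorophenyl in place of butyl on an aromatic carbon, on an aromatic carbon of a five-membered aromatic ring with 3 nitrogen. Among the measured compounds shown here, two measured steps touch this site. Lengthening the chain by one carbon changed nothing beyond the scatter, while replacing the chain end with hydroxy gave a large rise. Neither step places an aromatic ring there, so the measured steps give only a loose guide.

Because a number 1.5 percentage points higher from compound 1 to compound 2 (within the scatter) shows the number staying level when a larger carbon group sits at this site, the step from compound 1 to compound 4 is expected to be a number 8.5 percentage points higher from compound 1 to compound 4 (within the scatter). Compound 4 is therefore estimated at 5%, within -10% to 25%.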

Compound 4, a percentage reported as inhibition, at one concentration (the size of the read-out at that concentration, not a potency): 6.84%
Estimate against measurement, compound 4: 1.8 percentage points below, within the range that was stated.
By their numbers in this assay, from the lowest: compounds 1, 2 and 4 (each within the scatter of the next, the first and the last beyond it); then compound 3.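

On this aromatic carbon, in this assay, 3-fluorophenyl in place of butyl gives a number 10.3 percentage points higher from compound 1 to compound 4 (beyond the scatter) while 3-fluorophenyl in place of pentyl gives a number 8.8 percentage points higher from compound 2 to compound 4 (within the scatter) so the ring stands clear of only one of the two alkyl chains, and only just. 3-Fluorophenyl in place of 3-hydroxypropyl gives a number 20.6 percentage points lower from compound 3 to compound 4 (beyond the scatter) and so, among these four, the chain ending in hydroxy on compound 3 still gives the highest number, and an aromatic ring at this site does not reach it. Nothing measured here explains these differences.

From the compounds shown here alone, whether the fluorine contributes anything stays open, since a plain phenyl ring at this site would be needed to separate it from the ring itself. Also open, going by these compounds, is whether an amine or a carboxylic acid at the end of the propyl chain would match the rise seen with hydroxy.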